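Swapping the anilino aryl group on a shared quinazoline-free core

This account rests on a few compounds, and the source may have more. Where it says the series, first, only, none or still open, it means among the compounds named here.

Measured compounds:
Compound 1, `CCS(=O)(=O)Nc1cc(-c2ccc3ncnc(Nc4ccc(OC)cc4)c3c2)cnc1OC`: 1610 nM
Compound 2, `CCS(=O)(=O)Nc1cc(-c2ccc3ncnc(Nc4cccc(C(=O)OC)c4)c3c2)cnc1OC`: 2400 nM

Two compounds share the same core and differ only in the aryl group on a nitrogen on an aromatic ring. In a functional assay on SK-HEP1 cells (Homo sapiens) for cytotoxicity, read by sulforhodamine B assay, with a stated time of 72 h (a lower number here means a stronger inhibitor, a higher number a weaker inhibitor), compound 1 gives 1610 nM, and compound 2 gives 2400 nM. Among the measured compounds shown here, the single measured step, a 1.5-fold higher number from compound 1 to compound 2 (0.17 log units; within the scatter), so compound 2 has the higher of the two numbers but the two compounds cannot be told apart on these data.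

Compound 3, `CCS(=O)(=O)Nc1cc(-c2ccc3ncnc(Nc4ccc(F)nc4)c3c2)cnc1OC`, has not yet been measured in this assay. It differs from compound 2 by 6-fluoropyridin-3-yl in place of 3-(methoxycarbonyl)phenyl on a nitrogen on an aromatic ring. For the measured compounds named here, the only step that bears on this change is a 1.5-fold higher number from compound 1 to compound 2 (0.17 log units; within the scatter), where one aryl group on that nitrogen replaced another without a step beyond the scatter. Going by the values given here, no measured pair shows a pyridinyl group in this position. On that basis the step to compound 3 is expected to be small: compound 3 is estimated at 2000 nM, within a range of 700 nM to 6000 nM, which corresponds to an expected step of a 1.2-fold lower number from compound 2 to compound 3 (0.08 log units; within the scatter).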

Compound 3, half-maximal inhibitory concentration: 5240 nM
For compound 3 the middle estimate is 2.6-fold (0.42 log units) below the measured one; low and high end bracket the measured number.
By their numbers in this assay, from the lowest: compounds 1 and 2 (each within the scatter of the next); then compound 3.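

In this assay, the aryl group on a nitrogen on an aromatic ring now proves able to shift the number beyond the scatter, which compound 1 and compound 2 alone did not show. Moving to the 6-fluoropyridin-3-yl group gives a 2.2-fold higher number from compound 2 to compound 3 (0.34 log units; beyond the scatter) and also a 3.3-fold higher number from compound 1 to compound 3 (0.51 log units; beyond the scatter), so both steps are modest and both run towards a weaker inhibitor, whichever of the two phenyl groups it replaces. Nothing available here accounts for this shift.

The change brings in a ring nitrogen and a fluorine together and removes the earlier substituents, so these compounds leave open which part of it carries the step, and a pyridinyl ring without fluorine or a phenyl ring bearing fluorine would be needed to separate the two. It also remains open how the number would respond on this nitrogen to an aryl ring carrying an amine or a carboxylic acid, since only three aryl groups are shown on the shared core.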